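Moving the methoxy group: compound 3 to compound 4

A few compounds are considered here, and "the series" means these few. Any claim that something is new, unique, unknown or untested is made for them only; others in the source may bear on it.

Measured so far in a functional assay on DU-145 cells (Homo sapiens) for inhibition, read by trypan blue exclusion, with a stated time of 96 h; on this read-out lower numbers stand for stronger inhibition of growth and higher numbers for weaker inhibition of growth:
- compound 1 `COc1ccc(/C=C(/SCc2ccc(F)cc2)C(=O)c2ccc(Br)cc2)cc1O`: 1000 nM
- compound 2 `O=C(/C(=C\c1ccc(O)cc1)SCc1ccc(F)cc1)c1ccc(Br)cc1`: 10000 nM
- compound 3 `COc1ccc(/C=C(/SCc2ccc(F)cc2)C(=O)c2ccc(Br)cc2)cc1`: 50000 nM

Compound 3 gives the highest number of the three in this assay. The step of a 50-fold higher number from compound 1 to compound 3 (1.70 log units; beyond the scatter) is the largest within the set, and the step of a 5.0-fold higher number from compound 2 to compound 3 (0.70 log units; beyond the scatter) is modest; both leave compound 3 with the weakest growth inhibition measured here. The step of a 10-fold higher number from compound 1 to compound 2 (1.00 log units; beyond the scatter) is also modest.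

Compound 4 `COc1ccccc1/C=C(/SCc1ccc(F)cc1)C(=O)c1ccc(Br)cc1` is not yet measured. It differs from compound 3 in one place: 2-methoxyphenyl in place of 4-methoxyphenyl on a double-bonded chain carbon bound to a double-bonded chain carbon. Nothing in the measured steps bears directly on this change. Every step recorded so far concerns the presence or absence of a hydroxy group, or the methylation of that hydroxy group, on the same aromatic ring; none moves a methoxy group to another position while keeping the atom count unchanged. Without such a precedent, no step beyond the scatter in this assay is expected, in either direction.

For compound 4 the expected value in this assay is therefore 50000 nM, with a range from 15000 nM to 150000 nM. The step of no change at the digits printed from compound 3 to compound 4 (within the scatter) is expected to stay within the scatter.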

Compound 4, concentration for 50% growth inhibition: 10000 nM
Beside the measured number, compound 4's estimate is 5.0-fold (0.70 log units) above it; the whole stated range lies above it.
By their numbers in this assay, from the lowest: compound 1; then compounds 2 and 4 (each within the scatter of the next); then compound 3.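

In this assay, among the compounds shown here, the placing of the methoxy group on the aromatic ring matters: a 5.0-fold lower number from compound 3 to compound 4 (0.70 log units; beyond the scatter), the first step to come from moving a group with the same atoms rather than from adding, removing or methylating a hydroxy group. For the compounds shown here, the 2-methoxyphenyl and 4-hydroxyphenyl groups cannot be told apart here, with no change at the digits printed from compound 2 to compound 4 (within the scatter), so a free hydroxy group is not needed to reach this value, while a 10-fold higher number from compound 1 to compound 4 (1.00 log units; beyond the scatter) leaves the 3-hydroxy-4-methoxyphenyl group of compound 1 as the only one whose number lies below all the others beyond the scatter. No evidence is available that accounts for the difference between the 2-methoxyphenyl and 4-methoxyphenyl groups.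

The compounds shown leave open how a 3-methoxyphenyl group would compare with the 2-methoxyphenyl and 4-methoxyphenyl groups, and so whether the number follows the methoxy placing in any regular way. They also leave open whether an amine in place of the hydroxy group would hold the value of compound 1 (1000 nM), and how far any of these ring effects carry over when the rest of the shared core changes.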